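The compounds below may be only part of what the source reports. "The series", "measured", "known", "first", "only" and "open" are said of these compounds alone.

Compound 1 `COc1cc(C(=O)N/N=C/c2ccccc2C(F)(F)F)cc(OC)c1OC`: 45%
Compound 2 `COc1cc(C(=O)N/N=C/c2cccc(F)c2)cc(OC)c1OC`: 53.5%
Compound 3 `COc1cc(C(=O)N/N=C/c2cccc(C(F)(F)F)c2)cc(OC)c1OC`: 51%

Three hydrazones built on one shared core have been tested in a functional assay on PC-3 cells (Homo sapiens) for antiproliferative activity, read by MTT assay, tested at 1 uM; a lower number here means a weaker effect, a higher number a stronger effect of the compound at the concentration tested. Compound 2 holds the highest of the three numbers, but nothing separates it from the others beyond the scatter: compound 3 sits a number 2.5 percentage points lower from compound 2 to compound 3 (within the scatter), and compound 1 is the furthest away while still within the scatter of compound 2.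

Compound 4 `COc1cc(C(=O)N/N=C/c2ccccc2F)cc(OC)c1OC` has not yet been measured. It keeps the same atoms as compound 2 but joins them differently: 2-fluorophenyl in place of 3-fluorophenyl on a carbon with a double bond to nitrogen.

For the measured compounds named here, the one measured step, trifluoromethyl in place of fluoro, concerns a different kind of change and says little here. The pair compound 3 and compound 1 shows what moving the trifluoromethyl group between these two ring positions did: compound 3 gives 51% and compound 1 gives 45%, two numbers within the scatter of each other. By that analogy the fluoro group moved the same way is expected to give no step beyond the scatter, perhaps a slight drift downwards, a number 5.5 percentage points lower from compound 2 to compound 4 (within the scatter). Compound 4 is therefore estimated at 48%, with a range from 36% to 60%.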

Compound 4, a percentage reported as inhibition, at one concentration (the size of the read-out at that concentration, not a potency): 70.6%
The estimate for compound 4 lay 22.6 percentage points below the measured number; measured number above the stated range.
By their numbers in this assay, from the lowest: compounds 1, 3 and 2 (each within the scatter of the next); then compound 4.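

For the compounds shown here, exchanging 3-fluorophenyl for 2-fluorophenyl on a carbon with a double bond to nitrogen produced the first step beyond the scatter in this assay, a number 17.1 percentage points higher from compound 2 to compound 4 (beyond the scatter), so the same atoms joined differently can matter even though the earlier compounds gave no sign of it. Fluoro in place of trifluoromethyl on an aromatic carbon, which had changed nothing measurable in the only earlier pair, also gave a step beyond the scatter, a number 25.6 percentage points higher from compound 1 to compound 4 (beyond the scatter). The size of this exchange therefore depends on the core that carries it, and the two steps cannot be treated as one general effect of the group: the same change on two cores in this assay, a number 2.5 percentage points lower (within the scatter) from compound 2 to compound 3 and a number 25.6 percentage points lower (beyond the scatter) from compound 4 to compound 1, 23.1 percentage points apart, beyond the scatter of two such steps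

The compounds shown carry only fluoro and trifluoromethyl on this ring, so they leave open whether chloro, methoxy or hydroxyl in the place of the fluoro in compound 4 would keep the higher number. With a read-out at a single concentration, they also leave open how compound 4 and compound 2 would compare across a range of concentrations.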